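Following a climbing series to compound 4

This account rests on a few compounds, and the source may have more. Where it says the series, first, only, none or still open, it means among the compounds named here.

compound 1 `NC(=O)C1=CN(C[C@H](NC(=O)[C@@H]2CCC(=O)N2)C(=O)N2CCC[C@H]2C(N)=O)C=CC1` gives -3.29
compound 2 `NC(=O)C1=CN(CCC(NC(=O)[C@@H]2CCC(=O)N2)C(=O)N2CCC[C@H]2C(N)=O)C=CC1` gives -2.84
compound 3 `NC(=O)C1=CN(CCC[C@H](NC(=O)[C@@H]2CCC(=O)N2)C(=O)N2CCC[C@H]2C(N)=O)C=CC1` gives -2.39

In a physicochemical assay for lipophilicity (a lower number here means a more polar compound, a higher number a more lipophilic compound), compound 2 gives -2.84 as the second highest of the three numbers. Compound 3 at -2.39 lies above it and compound 1 at -3.29 lies below it, each gap beyond the scatter.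

Among the compounds with values here, compound 4 `NC(=O)C1=CN(CCCCC(NC(=O)[C@@H]2CCC(=O)N2)C(=O)N2CCC[C@H]2C(N)=O)C=CC1` has no measurement yet. It departs from compound 2 in one place, with a group of 11 heavy atoms (8 carbon, 2 nitrogen, 1 oxygen; one six-membered non-aromatic ring with 1 hetero atom) in place of a group of 9 heavy atoms (6 carbon, 2 nitrogen, 1 oxygen; one six-membered non-aromatic ring with 1 hetero atom), on a saturated chain carbon, three bonds along the chain from an amide-type nitrogen and a carbonyl carbon on a saturated chain carbon, three bonds along the chain from an amide-type nitrogen and a carbonyl carbon.

Within the data shown here, no measured pair differs in one place alone, so the expectation rests on the run of values. Among the measured compounds shown here, the run from compound 1 at -3.29 through compound 2 at -2.84 to compound 3 at -2.39 climbs evenly with no compound against it, so a further rise in this assay is expected. The estimated step is a number 0.89 log units higher from compound 2 to compound 4 (beyond the scatter) and it is expected to point upward, beyond the scatter. Compound 4 is expected near -1.95 with an estimated range from -2.25 to -1.65 in this measurement.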

Compound 4, partition coefficient: -1.94
The estimate for compound 4 lay 0.01 log units below the measured number, within the range that was stated.
By their numbers in this assay, from the lowest: compound 1; then compound 2; then compound 3; then compound 4.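

In this assay, within the data shown here, a group of 11 heavy atoms (8 carbon, 2 nitrogen, 1 oxygen; one six-membered non-aromatic ring with 1 hetero atom) in place of a group of 9 heavy atoms (6 carbon, 2 nitrogen, 1 oxygen; one six-membered non-aromatic ring with 1 hetero atom) gives a number 0.90 log units higher from compound 2 to compound 4 (beyond the scatter) as the first step that can be read at a single place. The number at this position thus responds to the added carbon atoms alone, since the hydrogen-bond donor, acceptor and double-bond counts and the net charge stay the same. No measurement here explains the size of this step.

A longer chain at this place could continue the rise or level off. An amine or a carboxylic acid on the chain remains an open comparison.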